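A few compounds are considered here, and "the series" means these few. Any claim that something is new, unique, unknown or untested is made for them only; others in the source may bear on it.

Compound 1 `CC(=O)c1cccc(-c2nc3c(N)ncnc3n2[C@@H]2O[C@H](COP(=O)(O)OP(=O)(O)OC[C@H]3OC(O)[C@H](O)[C@@H]3O)[C@@H](O)[C@H]2O)c1` carries a 3-acetylphenyl group on the shared core. In an assay on HEK293 cells for antagonist activity at transient receptor potential cation channel subfamily M member 2 (Homo sapiens), read by patch clamp (a lower number here means a stronger inhibitor, a higher number a weaker inhibitor), compound 1 gives 49000 nM, which is the only numerical result obtained so far and marks it as a weak inhibitor. A second molecule, compound 2 `Nc1ncnc2c1cc(Br)n2[C@@H]1O[C@H](COP(=O)(O)OP(=O)(O)OC[C@H]2OC(O)[C@H](O)[C@@H]2O)[C@@H](O)[C@H]1O`, is built differently; in this assay compound 2 is reported as "not active" (no number reported), with no number attached. Compound 3 `Nc1ncnc2c1nc(-c1ccccc1)n2[C@@H]1O[C@H](COP(=O)(O)OP(=O)(O)OC[C@H]2OC(O)[C@H](O)[C@@H]2O)[C@@H](O)[C@H]1O` has not yet been measured. It differs from compound 1 in one place: hydrogen in place of acetyl on an aromatic carbon. For the measured compounds named here, no measured pair shows what this change does, so the expectation rests on the weak starting point of compound 1 alone. The step is expected to be modest and more likely toward weaker inhibition, at roughly a 2.0-fold higher number from compound 1 to compound 3 (0.31 log units; beyond the scatter). Compound 3 is therefore estimated at 100000 nM in this assay, with a likely range from 30000 nM to 300000 nM, and a real chance that only an inactive result is reported.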

Compound 3, half-maximal inhibitory concentration: 11000 nM
Compound 3: the middle estimate sits 9.1-fold (0.96 log units) above what was measured; the whole stated range lies above it.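

Taking the acetyl group off the phenyl ring gives a 4.5-fold lower number from compound 1 to compound 3 (0.65 log units; beyond the scatter) in this assay, so the plain phenyl group of compound 3 inhibits more strongly than the 3-acetylphenyl group of compound 1. For the compounds shown here, this is the first sign that what sits at this place on the ring changes inhibition, and in this pair the acetyl group lowers it rather than adding to it. Nothing available explains why removing the acetyl group has this effect.

Going by these compounds alone, with only this one pair, it remains open whether the same step would appear with the acetyl group elsewhere on the ring. It is also unknown whether a group such as an amine, a carboxylic acid or a longer chain at this place would match hydrogen or improve on it.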